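Compound 2 to Compound 4: Chloro in Place of Nitro

The source may report more compounds than this note shows. Statements on the series, on what has been measured and on what is new or still open speak of the compounds shown alone.

Three measured compounds share one core and differ only in the group on the outer aromatic ring. Compound 1 `CCCCc1ccc(C(=O)/C=C/c2ccc([N+](=O)[O-])s2)cc1` gives 17100 nM in an ADME assay on THP-1 cells (Homo sapiens) for cytotoxicity, read by resazurin assay, with a stated time of 72 h; a lower number here means that less compound is tolerated, a higher number that more compound is tolerated. Compound 2 `O=C(/C=C/c1ccc([N+](=O)[O-])s1)c1ccc(-n2ccnc2)cc1` gives 23400 nM in this assay, and compound 3 `CSc1ccc(C(=O)/C=C/c2ccc([N+](=O)[O-])s2)cc1` gives 8560 nM in this assay. Compound 2 therefore holds the highest of the three numbers: the step of a 1.4-fold higher number from compound 1 to compound 2 (0.14 log units; within the scatter) is within the scatter, whereas the step of a 2.7-fold lower number from compound 2 to compound 3 (0.44 log units; beyond the scatter) is beyond it; the step of a 2.0-fold lower number from compound 1 to compound 3 (0.30 log units; within the scatter) is within the scatter.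

Compound 4 `O=C(/C=C/c1ccc(Cl)s1)c1ccc(-n2ccnc2)cc1` is not yet measured. Its change from compound 2 is chloro in place of nitro on an aromatic carbon. Among the compounds with values here, none of the three measured steps touches this ring; all of them exchange the group on the other aromatic carbon, so no step bears on the change at hand. With nothing in the data pointing either way, the expected step is none beyond the scatter, a 1.0-fold lower number from compound 2 to compound 4 (0.01 log units; within the scatter). The estimate for compound 4 in this assay is therefore 23000 nM, expected to lie between 9000 nM and 60000 nM.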

Compound 4, half-maximal cytotoxic concentration: > 50000 nM
Compound 4 was reported as a limit; the forecaster's own chance of this, stated with the estimate: 10%; middle value at least 2.1-fold (0.33 log units) away from the limit.
By their numbers in this assay, from the lowest: compounds 3, 1 and 2 (each within the scatter of the next, the first and the last beyond it). At a limit, above all of these: compound 4.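

The earlier compounds shown here varied only the group on the other aromatic carbon, and the largest of those steps was a 2.7-fold lower number from compound 2 to compound 3 (0.44 log units; beyond the scatter), so they said nothing about the position next to the ring sulfur. With chloro in place of nitro at this position, the result is an at least 2.1-fold higher number from compound 2 to compound 4 (0.32 log units; beyond the scatter), which shows that this position also moves the number in this assay, here towards more compound being tolerated. How far it moves stays unknown, as compound 4 is reported only as a limit: the limit of > 50000 nM in this assay, at which 1 of the 4 values shown sits.

The compounds shown leave open whether the same change would hold with butyl or methylsulfanyl on the other aromatic carbon, as chloro appears here only in compound 4. They also leave open how an amine, a carboxylic acid or a methoxy group would fare next to the ring sulfur.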